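Moving the Trifluoromethyl Group on the Sulfonyl Aryl Ring

The source may hold more compounds than are shown below. What is called first, only, known or untested is meant among the compounds shown, and "the series" means these compounds.

Measured in a functional assay on CWR22R cells (Homo sapiens) for antiproliferative activity, read by propidium iodide staining, with a stated time of 96 h; on this read-out lower numbers stand for stronger inhibition and higher numbers for weaker inhibition:
- compound 1 `CC(O)(CS(=O)(=O)c1ccc(F)cc1)C(=O)Nc1ccc(S(F)(F)(F)(F)F)cc1`: 20600 nM
- compound 2 `CC(O)(CS(=O)(=O)c1ccc(C(F)(F)F)cc1)C(=O)Nc1ccc(S(F)(F)(F)(F)F)cc1`: 28900 nM
- compound 3 `CC(O)(CS(=O)(=O)c1cccc(C(F)(F)F)c1)C(=O)Nc1ccc(S(F)(F)(F)(F)F)cc1`: 23800 nM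

In this assay, compound 3 cannot be separated from the other two: the step of a 1.2-fold higher number from compound 1 to compound 3 (0.06 log units; within the scatter) and the step of a 1.2-fold lower number from compound 2 to compound 3 (0.08 log units; within the scatter) both lie within the scatter. Compound 4 `CC(O)(CS(=O)(=O)c1ccccc1C(F)(F)F)C(=O)Nc1ccc(S(F)(F)(F)(F)F)cc1` carries 2-(trifluoromethyl)phenyl in place of 3-(trifluoromethyl)phenyl on a sulfonyl sulfur. Among the compounds with values here, the closest precedent is the step of a 1.2-fold lower number from compound 2 to compound 3 (0.08 log units; within the scatter), which exchanges 4-(trifluoromethyl)phenyl for 3-(trifluoromethyl)phenyl, and the step of a 1.4-fold higher number from compound 1 to compound 2 (0.15 log units; within the scatter) is also small. Within the data shown here, no measured compound carries the entering group, so this remains an extrapolation. The expected step, a 1.0-fold higher number from compound 3 to compound 4 (0.00 log units; within the scatter), is not expected to exceed the scatter, in either direction. For compound 4 the estimated value is 24000 nM, with an expected range of 14000 nM to 41000 nM.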

Compound 4, half-maximal inhibitory concentration: 17400 nM
The estimate for compound 4 lay 1.4-fold (0.14 log units) above the measured number; the measured number falls inside the stated range.
By their numbers in this assay, from the lowest: compounds 4, 1, 3 and 2 (each within the scatter of the next).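

In this assay the 2-(trifluoromethyl)phenyl group on the sulfonyl sulfur stands with the other two trifluoromethyl groups: a 1.4-fold lower number from compound 3 to compound 4 (0.14 log units; within the scatter) and a 1.7-fold lower number from compound 2 to compound 4 (0.22 log units; within the scatter) both lie within the scatter, and so does a 1.2-fold lower number from compound 1 to compound 4 (0.07 log units; within the scatter) against the 4-fluorophenyl group. Among compounds 2, 3 and 4, moving trifluoromethyl around this aryl ring therefore does not separate them in this assay at all. Nothing available here explains this flat result. The compounds shown leave open whether an amine or a carboxylic acid on this ring would give a step beyond the scatter.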